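Methyl in place of amino on the compound 1 core

The source may report more compounds than this note shows. Statements on the series, on what has been measured and on what is new or still open speak of the compounds shown alone.

Measured so far in a functional assay on HEK293 cells for agonist activity at G-protein coupled receptor 84 (Homo sapiens), read by calcium flux; a lower number here means that less compound is needed, a higher number that more compound is needed for the effect:
compound 1, `Nc1cc(O)nc(SCCCCc2ccccc2)n1`: > 100000 nM, a limit of the assay
compound 2, `Nc1cc(N)nc(SCCCCc2ccccc2)n1`: > 100000 nM, a limit of the assay
compound 3, `CCCCCCCc1cc(O)cc(O)n1`: 1.26 nM

Compound 1 stands only as a limit in this assay; no number is known for it. Of the three values shown, two sit at that limit (the limit of > 100000 nM in this assay, at which 2 of the 3 values shown sit), and compound 3 alone gives a measured number. For the measured compounds named here, the one step computed among the measured compounds, a step that the two limits leave unreadable from compound 1 to compound 2, is unreadable, since both of its ends are limits.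

Compound 4, `Cc1cc(O)nc(SCCCCc2ccccc2)n1`, differs from compound 1 in one place: methyl in place of amino on an aromatic carbon. Going by the values given here, no measured step shows the effect of that change, and the step from compound 1 to compound 2, which alters the same position, gives no readable size. Among the compounds with values here, the only guidance is that compound 1 itself sits at the limit, so a methyl in place of the amino is expected to leave the value near where compound 1 stands, with a real chance that this assay again reports only a limit.

For compound 4 in this assay the estimate is 60000 nM, with a range from 3000 nM to 300000 nM. That estimate means an expected step of an at least 1.6-fold lower number from compound 1 to compound 4 (0.22 log units; that floor lies within the scatter), which is not readable against a limit.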

Compound 4, half-maximal effective concentration: > 100000 nM
Compound 4 gave a limit, no number (the forecaster's own chance of this, stated with the estimate: 65%); middle value at least 1.6-fold (0.22 log units) from the limit.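

Compound 1 and compound 4 both stand only as limits in this assay, so no step between them can be read: the limit of > 100000 nM in this assay, at which 3 of the 4 values shown sit.

The compounds shown leave open whether methyl or amino in that place changes the value at all in this assay, and whether any compound on the shared core of compound 1 gives a measured number.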